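Shifting the chlorine on the benzyl group of compound 2

The compounds below may be only part of what the source reports. "The series", "measured", "known", "first", "only" and "open" are said of these compounds alone.

Measured so far in a functional assay on BGC-823 cells (Homo sapiens) for antiproliferative activity, read by MTT assay, with a stated time of 24 h; on this read-out higher numbers stand for weaker inhibition and lower numbers for stronger inhibition:
- compound 1 `O=[N+]([O-])c1ccc(CSc2nnc(-c3ccc4c(c3)OCCO4)n2-c2ccccc2)cc1`: 48600 nM
- compound 2 `Clc1ccccc1CSc1nnc(-c2ccc3c(c2)OCCO3)n1-c1ccccc1`: 17400 nM

Of these two, compound 2 has the lower number, 17400 nM, and so shows the stronger inhibition. Compound 3 `Clc1cccc(CSc2nnc(-c3ccc4c(c3)OCCO4)n2-c2ccccc2)c1` keeps the same atoms but joins them differently, with 3-chlorophenyl in place of 2-chlorophenyl on a saturated chain carbon bound to a sulfur.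

For the measured compounds named here, only one measured step bears on this change: a 2.8-fold lower number from compound 1 to compound 2 (0.45 log units; beyond the scatter). It was modest and occurred at the same place, but it exchanged a different pair of groups. Going by the values given here, no measured compound shows what shifting the chlorine does, so no direction can be favoured, and a step beyond the scatter in this assay is not expected. The expected change is small, a 1.1-fold higher number from compound 2 to compound 3 (0.06 log units; within the scatter). For compound 3 the estimated value is 20000 nM, with an expected range of 8000 nM to 50000 nM.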

Compound 3, half-maximal inhibitory concentration: 51200 nM
Compound 3: middle estimate off by 2.6-fold (0.41 log units), on the low side, outside the stated range (above it).
By their numbers in this assay, from the lowest: compound 2; then compounds 1 and 3 (each within the scatter of the next).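

In this assay, moving the chlorine on its own is not a neutral change at this position: 3-chlorophenyl in place of 2-chlorophenyl gives a 2.9-fold higher number from compound 2 to compound 3 (0.47 log units; beyond the scatter) and so removes the advantage of compound 2, although the atoms stay the same. Exchanging the 4-nitrophenyl group for 3-chlorophenyl gives a 1.1-fold higher number from compound 1 to compound 3 (0.02 log units; within the scatter) and so a chlorine on the ring does not by itself set compound 2 apart; among these three compounds, only the 2-chlorophenyl group stands out. Nothing available here explains why the place of the chlorine matters.

Going by these compounds, it remains open whether a plain benzyl group without chlorine would side with compound 2 or with compound 3. On these data alone, the effect of an amine or a carboxylic acid on this ring, or of a longer chain to the sulfur, also remains unknown.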